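The source may hold more compounds than are shown below. What is called first, only, known or untested is meant among the compounds shown, and "the series" means these compounds.

Measured so far:
Compound 1 `CCCCCCCC/C=C\CCCCCCC(=O)c1nc(-c2ccccc2)c(-c2ccccc2)o1` — > 100000 nM
Compound 2 `CCCCCCCC/C=C\CCCCCCC(=O)c1nc2cccnc2o1` — 11 nM

In an assay on isolated protein for inhibition of Fatty-acid amide hydrolase 1 (Homo sapiens) (on this read-out higher numbers stand for weaker inhibition and lower numbers for stronger inhibition), compound 1 gives only a limit of > 100000 nM, not a number, which is the limit of > 100000 nM in this assay, at which 1 of the 2 values shown sits. In this assay, among the measured compounds shown here, compound 2 gives 11 nM, the only actual number among the values shown. Compound 3 `CCCCCCCC/C=C\CCCCCCC(=O)c1nc2ccccc2o1` is not yet measured. It differs from compound 2 by a group of 9 heavy atoms (7 carbon, 1 nitrogen, 1 oxygen; one five-membered aromatic ring with 2 hetero atoms, one six-membered aromatic ring of carbon only) in place of a group of 9 heavy atoms (6 carbon, 2 nitrogen, 1 oxygen; one five-membered aromatic ring with 2 hetero atoms, one six-membered aromatic ring with 1 hetero atom), on a carbonyl carbon. For the measured compounds named here, no measured pair shows this kind of change, so the expected step from compound 2 to compound 3 is a guess: a loss of inhibition beyond the usual scatter, about a 7.3-fold higher number from compound 2 to compound 3 (0.86 log units; beyond the scatter). Compound 3 is therefore expected to give roughly 80 nM, plausibly between 20 nM and 400 nM.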

Compound 3, inhibition constant: 370 nM
For compound 3 the middle estimate is 4.6-fold (0.67 log units) below the measured one; the range from low to high includes it.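

In this assay, the step shows that this position on the carbonyl carbon responds strongly to a single atom: a 34-fold higher number from compound 2 to compound 3 (1.53 log units; beyond the scatter). The two groups have the same number of heavy atoms and the same ring sizes, and the hetero atom of the six-membered ring in compound 2 is the only thing that gives way to carbon. Nothing measured here explains why the step is so large. From the compounds shown here alone, it remains open what a chlorine or a methoxy group on the six-membered ring of compound 3 would do, and whether a shorter chain would leave this step unchanged.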